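From compound 2 to compound 3: one methyl fewer on the amide

The source may report more compounds than this note shows. Statements on the series, on what has been measured and on what is new or still open speak of the compounds shown alone.

Measured in an in vitro ADME assay on microsomes from liver (Rattus norvegicus) for metabolic stability; a lower number here means slower removal, a higher number faster removal of the compound
compound 1 `CC[C@H](C)[C@@H]1C(=O)N[C@H](C2Cc3ccccc3C2)C(=O)N1[C@@H](C(=O)N1CCOCC1)c1cnc(C)cc1C` gives 1 mL.min-1.g-1
compound 2 `CC[C@H](C)[C@@H]1C(=O)N[C@H](C2Cc3ccccc3C2)C(=O)N1[C@@H](C(=O)N(C)C)c1cnc(C)cc1C` gives 1 mL.min-1.g-1

Compound 2 stands level with compound 1 at the digits shown, and nothing separates the two on these numbers. Compound 3 `CC[C@H](C)[C@@H]1C(=O)N[C@H](C2Cc3ccccc3C2)C(=O)N1[C@@H](C(=O)NC)c1cnc(C)cc1C` carries hydrogen in place of methyl on an amide-type nitrogen and otherwise matches compound 2. Going by the values given here, no measured pair shows this exchange itself, so the guide is indirect. Among the compounds with values here, the one step available is no change at the digits printed from compound 1 to compound 2 (within the scatter) with dimethylamino in place of morpholin-4-yl on a carbonyl carbon. Resting on that single step, no change beyond the scatter is expected in this assay for the new compound. The expected step is no change at the digits printed from compound 2 to compound 3 (within the scatter) on this reading. For compound 3 the estimate is 1 mL.min-1.g-1 with an expected range from 0.5 mL.min-1.g-1 to 3 mL.min-1.g-1 in this read-out.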

Compound 3, intrinsic clearance in microsomes: 1 mL.min-1.g-1
The estimate for compound 3 equals the measured number at the digits printed, within the range that was stated.
By their numbers in this assay, from the lowest: compounds 1, 2 and 3 (each within the scatter of the next).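

In this assay, going by these compounds alone, the amide nitrogen carries a hydrogen for the first time, and the exchange of dimethylamino for methylamino reads (no change at the digits printed from compound 2 to compound 3 (within the scatter)). Measured against the morpholin-4-yl amide, the methylamino amide also reads (no change at the digits printed from compound 1 to compound 3 (within the scatter)), so morpholin-4-yl, dimethylamino and methylamino on the carbonyl carbon are not separated by this read-out, whether or not the amide hydrogen is present. No measured evidence bears on why these readings coincide.

Within the data shown here, with compound 3 at 1 mL.min-1.g-1, no step at this amide yet lies beyond the scatter, so the range this position can reach in this assay remains open. Going by these compounds, still open as well is how a primary carboxamide, a carboxylic acid or a longer chain such as butylamino would read here.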